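Swapping the aryl group on the piperazine nitrogen

This account rests on a few compounds, and the source may have more. Where it says the series, first, only, none or still open, it means among the compounds named here.

Of the compounds shown here, two sharing one core have been measured so far. Compound 1 `Nc1scc(CN2CCN(c3ccc(F)cc3Cl)CC2)c1C(=O)c1ccc(Cl)cc1` gives -70% in a functional assay on CHO cells with adenosine receptor A1 (Homo sapiens) as the target, read by cAMP accumulation and immunoassay, with a stated time of 6 min, tested at 10 uM; a higher number here means a weaker effect of the compound at the concentration tested, a lower number a stronger effect. Compound 2 `COc1ccc(N2CCN(Cc3csc(N)c3C(=O)c3ccc(Cl)cc3)CC2)cc1` gives -52% in the same setting, and the step of a number 18 percentage points higher from compound 1 to compound 2 (beyond the scatter) shows the two aryl groups on the ring nitrogen are not interchangeable. On the numbers shown, compound 2 stands highest, with compound 1 the only neighbour and sitting lower. Compound 3 `Nc1scc(CN2CCN(c3cccnc3)CC2)c1C(=O)c1ccc(Cl)cc1` has not yet been measured; it differs from compound 2 by pyridin-3-yl in place of 4-methoxyphenyl on an amine nitrogen in a ring. Within the data shown here, the only measured step that touches the same place is the one from compound 1 to compound 2, a modest shift, and it does not involve pyridin-3-yl. A change of similar or smaller size is therefore expected here, with the direction uncertain. Compound 3 is estimated to give -45%, between -70% and -20%, which would mean an expected step of a number 7 percentage points higher from compound 2 to compound 3 (within the scatter).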

Compound 3, a percentage reported as activity, at one concentration (the size of the read-out at that concentration, not a potency): -23%
Compound 3: middle estimate off by 22 percentage points, on the low side; measured number inside the range.
By their numbers in this assay, from the lowest: compound 1; then compound 2; then compound 3.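

In this assay, putting a ring nitrogen into the aryl group on this amine nitrogen matters: pyridin-3-yl in place of 4-methoxyphenyl gives a number 29 percentage points higher from compound 2 to compound 3 (beyond the scatter), and pyridin-3-yl in place of 2-chloro-4-fluorophenyl gives a number 47 percentage points higher from compound 1 to compound 3 (beyond the scatter). Compound 3 therefore has the weakest effect of the three at the concentration tested, so this position can change the read-out far more than the first pair showed, and the change is not neutral even though the shared core stays the same. No measurement here explains the shift.

Still open, from the compounds shown here alone, is whether the ring nitrogen itself or the loss of the substituents on the aryl ring drives the change. An unsubstituted phenyl group or a pyridin-4-yl group at the same place would help separate the two.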